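A few compounds are considered here, and "the series" means these few. Any claim that something is new, unique, unknown or untested is made for them only; others in the source may bear on it.

Compound 1, `O=C(/C=C/c1ccc2c(c1)B(O)OC2)c1ccc(Br)cc1`, in a functional assay on SK-OV-3 cells (Homo sapiens) for cytotoxicity, read by MTT assay, with a stated time of 48 h (a higher number here means a weaker inhibitor, a lower number a stronger inhibitor), gives 4500 nM.
Compound 2, `Nc1ccc(C(=O)/C=C/c2ccc3c(c2)B(O)OC3)cc1`, gives 20200 nM.
Compound 3, `Cc1cccc(C(=O)/C=C/c2ccc3c(c2)B(O)OC3)c1`, gives 2900 nM.

On these numbers compound 3 has the lowest value of the three; one of its two gaps stays within the scatter (a 1.6-fold lower number from compound 1 to compound 3 (0.19 log units; within the scatter)), while the other is clear (a 7.0-fold lower number from compound 2 to compound 3 (0.84 log units; beyond the scatter)). Compound 4, `Nc1cccc(C(=O)/C=C/c2ccc3c(c2)B(O)OC3)c1`, differs from compound 3 by a single group: amino in place of methyl on an aromatic carbon. Among the compounds with values here, no measured pair swaps a methyl for an amino, but one step does bring an amino onto the same kind of ring: a 4.5-fold higher number from compound 1 to compound 2 (0.65 log units; beyond the scatter), a modest rise in the number. The amino-bearing compound 2 also stands furthest from compound 3 (a 7.0-fold lower number from compound 2 to compound 3 (0.84 log units; beyond the scatter)). Both observations point the same way, although the swap here sits meta to a large group, a different position from the amino of compound 2, so the size may differ. For compound 4 a rise in this assay beyond the scatter is expected, roughly a 3.1-fold higher number from compound 3 to compound 4 (0.49 log units; beyond the scatter). Compound 4 is therefore estimated at 9000 nM, within 3000 nM to 30000 nM.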

Compound 4, half-maximal inhibitory concentration: 7400 nM
Compound 4: middle estimate off by 1.2-fold (0.09 log units), on the high side; low and high end bracket the measured number.
By their numbers in this assay, from the lowest: compounds 3, 1 and 4 (each within the scatter of the next, the first and the last beyond it); then compound 2.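

Within the data shown here, the first direct reading of amino in place of methyl, meta to a large group, is a 2.6-fold higher number from compound 3 to compound 4 (0.41 log units; beyond the scatter) in this assay. The place of the amino also counts, since 3-aminophenyl in place of 4-aminophenyl gives a 2.7-fold lower number from compound 2 to compound 4 (0.44 log units; beyond the scatter), so the number depends on where the amino sits as well as on whether it is present. With 3-aminophenyl in place of 4-bromophenyl the result is a 1.6-fold higher number from compound 1 to compound 4 (0.22 log units; within the scatter), so this exchange cannot be told apart from the ordinary spread of repeated measurements.

On these data alone, what a hydroxyl, a methoxy or a carboxylic acid would do at this same position stays open. So does the question of whether an amine carrying a longer chain would behave like the plain amino. No measurement shown here explains any of these steps.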